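Chloro removal on the oxadiazole chromone sulfide

This account rests on a few compounds, and the source may have more. Where it says the series, first, only, none or still open, it means among the compounds named here.

Compound 2 `Cc1nnc(SCc2coc3ccc(Cl)cc3c2=O)o1` sits at the top of the two numbers in hand for a functional assay on HEp-2 cells (Homo sapiens) for cytotoxicity, read by MTT assay, with a stated time of 72 h (a lower number here means a stronger inhibitor, a higher number a weaker inhibitor), with compound 2 giving 6400 nM. Among the compounds with values here, its nearest neighbour is compound 3 `Cc1nnc(SCc2coc3ccc(Cl)cc3c2=O)s1`, which in this assay gives 4200 nM; the shift a 1.5-fold lower number from compound 2 to compound 3 (0.18 log units; within the scatter) is the only measured step, and it exchanges 5-methyl-1,3,4-thiadiazol-2-yl for 5-methyl-1,3,4-oxadiazol-2-yl on a sulfur while leaving the rest untouched. Compound 1 `O=c1cc(CSc2nc3ccccc3s2)oc2ccccc12` reaches only a limit of the assay, > 25000 nM, and so gives no number to compare; the limit of > 25000 nM in this assay, at which 1 of the 3 values shown sits, marks that boundary.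

The step to compound 4 `Cc1nnc(SCc2coc3ccccc3c2=O)o1` is a different kind of change: hydrogen in place of chloro on an aromatic carbon of a six-membered aromatic ring of carbon only, part of a fused or bridged system of two rings, meta to a fused ring and para to a fused ring. Within the data shown here, no measured step touches this position or this group; the thiadiazole-for-oxadiazole swap stayed within the scatter and says nothing about the halogen. The working expectation is therefore a step of a 1.4-fold higher number from compound 2 to compound 4 (0.15 log units; within the scatter) of no clear direction, with a wide band. Compound 4 is estimated at 9000 nM, between 3000 nM and 30000 nM.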

Compound 4, half-maximal inhibitory concentration: 3800 nM
The estimate for compound 4 lay 2.4-fold (0.37 log units) above the measured number; low and high end bracket the measured number.
By their numbers in this assay, from the lowest: compounds 4, 3 and 2 (each within the scatter of the next). At a limit, above all of these: compound 1.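

In this assay, the chloro position has its first reading, a 1.7-fold lower number from compound 2 to compound 4 (0.23 log units; within the scatter), with hydrogen in place of chloro on an aromatic carbon of the six-membered aromatic ring of carbon only. The chloro is therefore not needed for a measurable number on this oxadiazole sulfide: compound 4 has no chlorine, gives a number rather than a limit, and cannot be separated from compound 2 by this single step, just as the earlier heteroatom swap could not separate compound 2 from compound 3. Nothing at hand speaks to why this exchange leaves the two compounds within the scatter of each other.

Whether chloro and hydrogen are also equivalent on the thiadiazole sulfide remains open, since the series shown holds only the chloro form of that compound, and a single pair on the oxadiazole cannot be extended to it. Also open is how a bromo, a methoxy or an amine on the same aromatic carbon would read, as hydrogen and chloro are the only two groups shown at this position.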